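Two measured analogues and a nitro variant awaiting its number

The source may report more compounds than this note shows. Statements on the series, on what has been measured and on what is new or still open speak of the compounds shown alone.

Compound 1, `COc1cc(-c2nnc3n2NC(c2ccco2)C(C(=O)c2ccc(F)cc2)S3)cc(OC)c1OC`, was tested in a functional assay on PC-3 cells (Homo sapiens) for cytotoxicity, read by MTT assay, with a stated time of 48 h (a lower number here means a stronger inhibitor, a higher number a weaker inhibitor), and compound 1 gives 27700 nM. Compound 2, `COc1cc(-c2nnc3n2NC(c2cccs2)C(C(=O)c2ccc(F)cc2)S3)cc(OC)c1OC`, differs from it only on a saturated ring carbon, and in this assay compound 2 gives 27400 nM. Among the compounds with values here, the single step between them, a 1.0-fold lower number from compound 1 to compound 2 (0.00 log units; within the scatter), is within the scatter, so compound 1 stands with the higher of the two numbers but cannot be set apart from compound 2.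

Compound 3, `COc1cc(-c2nnc3n2NC(c2ccco2)C(C(=O)c2ccc([N+](=O)[O-])cc2)S3)cc(OC)c1OC`, keeps the shared core and the furan-2-yl group of compound 1 and changes only the aryl ketone: nitro in place of fluoro on an aromatic carbon. No measured step alters this part of the molecule, so nothing shown bears directly on the change; the one step measured, on the saturated ring carbon, was within the scatter. With no evidence for a shift in either direction, compound 3 is expected to land near compound 1, and the estimated step is a 1.0-fold lower number from compound 1 to compound 3 (0.01 log units; within the scatter). Compound 3 is therefore estimated at 27000 nM, with a range from 9000 nM to 80000 nM.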

Compound 3, half-maximal inhibitory concentration: 27900 nM
The estimate for compound 3 lay 1.0-fold (0.01 log units) below the measured number; measured number inside the range.
By their numbers in this assay, from the lowest: compounds 2, 1 and 3 (each within the scatter of the next).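

In this assay, within the data shown here, nitro in place of fluoro on an aromatic carbon, para to a large group, gives a 1.0-fold higher number from compound 1 to compound 3 (0.00 log units; within the scatter), the first measured change to the aryl ketone. Going from 4-fluorophenyl to 4-nitrophenyl therefore replaces a single atom with a larger group that carries hydrogen-bond acceptors, yet the two numbers cannot be told apart, and the same holds for the earlier step on the saturated ring carbon, so compounds 1, 2 and 3 all sit within the scatter of their neighbours in this series. Nothing measured here accounts for why the numbers for these two substituents coincide.

The compounds shown leave open whether an amine or a carboxylic acid on this same aromatic carbon would give a number set apart from those of the fluoro and nitro compounds. They also leave open whether 4-nitrophenyl combined with thiophen-2-yl on the saturated ring carbon would stay with these three compounds, and whether any change to the shared core itself would move the number beyond the scatter.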